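The compounds below may be only part of what the source reports. "The series", "measured", "known", "first", "only" and "open" are said of these compounds alone.

Compound 3, `O=C1N=C(N2CCC[C@H]2C(=O)Nc2ccc3ncnc(Nc4cccc(Cl)c4)c3c2)S/C1=C/c1ccccc1Br`, stands at the edge of what a functional assay on A549 cells (Homo sapiens) for antiproliferative activity, read by MTT assay (a lower number here means a stronger inhibitor, a higher number a weaker inhibitor), can report: it gives > 50000 nM, which is a limit of the assay rather than a number. Its two companions share the same core. Compound 1, `O=C1N=C(N2CCC[C@H]2C(=O)Nc2ccc3ncnc(Nc4cccc(Cl)c4)c3c2)S/C1=C/c1ccc(Br)s1`, also reaches only a limit, giving > 50000 nM in this assay. Compound 2, `O=C1N=C(N2CCC[C@H]2C(=O)Nc2ccc3ncnc(Nc4cccc(Cl)c4)c3c2)S/C1=C/c1ccccc1Cl`, likewise gives > 50000 nM, again a limit. All three thus sit at the limit of > 50000 nM in this assay, at which 3 of the 3 values shown sit. The steps among them, a step that the two limits leave unreadable from compound 1 to compound 2, a step that the two limits leave unreadable from compound 1 to compound 3 and a step that the two limits leave unreadable from compound 2 to compound 3, cannot be read for size or direction. Compound 4, `O=C1N=C(N2CCC[C@H]2C(=O)Nc2ccc3ncnc(Nc4cccc(Cl)c4)c3c2)S/C1=C/c1cccc(Br)n1`, differs from compound 3 by 6-bromopyridin-2-yl in place of 2-bromophenyl on a double-bonded chain carbon bound to a double-bonded ring carbon. For the measured compounds named here, no measured step bears a readable size on this exchange, so nothing points to a gain or a loss; three compounds at the limit leave the expectation that compound 4 remains there as well. The step from compound 3 to compound 4 is expected to be a step that the limit leaves unreadable from compound 3 to compound 4. Compound 4 is therefore estimated at 60000 nM, with a range from 20000 nM to 200000 nM, and most likely it is again reported only as a limit.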

Compound 4, half-maximal inhibitory concentration: 3100 nM
Compound 4: the middle estimate sits 19-fold (1.29 log units) above what was measured; measured number outside the range, below it.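

At this place, on a double-bonded chain carbon bound to a double-bonded ring carbon, the group now proves able to change the result in this assay: 6-bromopyridin-2-yl in place of 2-bromophenyl gives an at least 16-fold lower number from compound 3 to compound 4 (1.20 log units; beyond the scatter). The same group gives an at least 16-fold lower number from compound 2 to compound 4 (1.20 log units; beyond the scatter) against 2-chlorophenyl and an at least 16-fold lower number from compound 1 to compound 4 (1.20 log units; beyond the scatter) against 5-bromothiophen-2-yl, and each of these sizes is only a minimum, set by a limit of the assay. Compound 4 alone among the four has left that limit, while the steps among the other three remain unreadable: the limit of > 50000 nM in this assay, at which 3 of the 4 values shown sit.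

The entering group differs from 2-bromophenyl both in its ring hetero atom and in the numbering of its bromo, and the compounds shown do not separate the two, as 3-bromophenyl or pyridin-2-yl could. From the compounds shown here alone, whether 6-chloropyridin-2-yl would keep the gain also stays open.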